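The compounds below may be only part of what the source reports. "The series", "measured", "known", "first", "only" and "open" are said of these compounds alone.

In a functional assay on Gurav cells (Homo sapiens) for inhibition, read by sulforhodamine B assay (on this read-out higher numbers stand for weaker inhibition of growth and lower numbers for stronger inhibition of growth), compound 1 (`Fc1ccc(-c2ccc(-c3ccc(-c4nc5ccccc5[nH]4)cc3)cc2)cc1`) gives 100000 nM. Compound 2 (`Oc1ccc(-c2ccc(-c3ccc(-c4nc5ccccc5[nH]4)cc3)cc2)cc1`) stands level with it at 100000 nM, while compound 3 (`COc1ccc(-c2ccc(-c3ccc(-c4nc5ccccc5[nH]4)cc3)cc2)cc1OC`) gives 9230 nM, so compound 1 shares the highest number of the three. Compound 4 (`Oc1cccc2[nH]c(-c3ccc(-c4ccc(-c5ccc(F)cc5)cc4)cc3)nc12`) differs from compound 1 in a single place: hydroxy in place of hydrogen on an aromatic carbon. For the measured compounds named here, no measured compound carries a new group at that place, so the evidence is indirect. Going by the values given here, the closest precedent also brings in a hydroxy, though at a different place, and it shows no change at the digits printed from compound 1 to compound 2 (within the scatter). The two other steps, an 11-fold lower number from compound 1 to compound 3 (1.03 log units; beyond the scatter) and an 11-fold lower number from compound 2 to compound 3 (1.03 log units; beyond the scatter), show that the number can fall substantially in this series, but both involve 3,4-dimethoxyphenyl, not a lone hydroxy. In this assay, a small move towards a lower number is therefore expected, probably none beyond the scatter. For compound 4 the estimated value is 60000 nM, with an expected range from 15000 nM to 100000 nM. The expected change is a 1.7-fold lower number from compound 1 to compound 4 (0.22 log units; within the scatter).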

Compound 4, concentration for 50% growth inhibition: 2860 nM
Compound 4: middle estimate off by 21-fold (1.32 log units), on the high side; measured number below the stated range.
By their numbers in this assay, from the lowest: compound 4; then compound 3; then compounds 1 and 2 (each within the scatter of the next).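

In this assay, a hydroxy on an aromatic carbon of a six-membered aromatic ring of carbon only, part of a fused or bridged system of two rings, gives a 35-fold lower number from compound 1 to compound 4 (1.54 log units; beyond the scatter), so a single added group at this position can move the number far. The hydroxy in the earlier pair, which stands at a different place, gave no change at the digits printed from compound 1 to compound 2 (within the scatter), so among these compounds the outcome of bringing in a hydroxy depends on where it goes. Nothing shown here bears on the reason for this large step.

Going by these compounds, it remains open whether the hydroxy is specifically needed here, or whether an amine or a carboxylic acid at the same position would give a similar number. On these data alone, it is also open whether the same hydroxy would act alike in compound 3, which carries 3,4-dimethoxyphenyl in place of 4-fluorophenyl.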